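A few compounds are considered here, and "the series" means these few. Any claim that something is new, unique, unknown or untested is made for them only; others in the source may bear on it.

Compound 1 `O=C(/C=C/c1ccccc1-c1ccc(F)nc1)c1cccc(O)c1` and compound 2 `COc1ccc(C(=O)/C=C/c2ccccc2-c2ccc(F)nc2)cc1O` share one core. In a functional assay on SW480 cells (Homo sapiens) for antiproliferative activity, read by sulforhodamine B assay, with a stated time of 48 h (on this read-out higher numbers stand for weaker inhibition and lower numbers for stronger inhibition), compound 1 gives 7400 nM, and in this assay compound 2 gives 1600 nM. The change between them, (methoxy in place of hydrogen on an aromatic carbon), made the step of a 4.6-fold lower number from compound 1 to compound 2 (0.67 log units; beyond the scatter). Compound 3 `COc1ccc(CNC(=O)c2ccccc2-c2ccc(F)cc2)cc1OC` rests on another core; the difference between the two cores is not broken down here. In this assay compound 3 reaches only a limit of the assay, > 50000 nM. That limit is the limit of > 50000 nM in this assay, at which 1 of the 3 values shown sits. Compound 4 `COc1cc(CNC(=O)c2ccccc2-c2ccc(F)cc2)cc(OC)c1OC` is not yet measured and differs from compound 3 by methoxy in place of hydrogen on an aromatic carbon. This is the same kind of change as that from compound 1 to compound 2, though the surroundings differ: in compound 2 the new group is ortho to a hydroxy group and para to a large group, while in compound 4 it is ortho to a methoxy group, meta to a large group and meta to a methoxy group. The step from compound 3 to compound 4 is expected to be a number no higher from compound 3 to compound 4 (the limit leaves the size open), an estimate that rests on the step of a 4.6-fold lower number from compound 1 to compound 2 (0.67 log units; beyond the scatter) tempered by compound 3 standing at a limit. Compound 4 is therefore expected to give roughly 50000 nM, somewhere between 15000 nM and 150000 nM.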

Compound 4, half-maximal inhibitory concentration: > 50000 nM
Compound 4: only a limit was reported (the forecaster's own chance of this, stated with the estimate: 65%); the middle value sits exactly at the limit.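

In this assay, compound 3 and compound 4 each reach only a limit of the assay, so the step between them cannot be read: the limit of > 50000 nM in this assay, at which 2 of the 4 values shown sit.

The compounds shown leave open whether methoxy in place of hydrogen on an aromatic carbon changes the inhibition at all on the core of compound 3.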